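Cytotoxicity notes on the methoxymethyl analogue

The source may hold more compounds than are shown below. What is called first, only, known or untested is meant among the compounds shown, and "the series" means these compounds.

The series shares one core, and its compounds are compared in a toxicity assay on MT2 cells (Homo sapiens) for cytotoxicity, read by MTT assay; a higher number here means that more compound is tolerated, a lower number that less compound is tolerated. Compound 1 `Cc1cc(Oc2ccccc2OCCn2ccc(=O)[nH]c2=O)cc2cc(C#N)ccc12` gives 6000 nM in this assay. Compound 2 `N#Cc1ccc2c(F)cc(Oc3ccccc3OCCn3ccc(=O)[nH]c3=O)c(Cl)c2c1` reaches only a limit of this assay, > 100000 nM. Compound 3 `CCc1cc(Oc2ccccc2OCCn2ccc(=O)[nH]c2=O)c(C)c2cc(C#N)ccc12` gives 12000 nM in this assay; its gap to compound 1 sits within the scatter, so the two stand together. The remaining value of the three is a limit, (the limit of > 100000 nM in this assay, at which 1 of the 3 values shown sits).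

Compound 4 `COCc1cc(Oc2ccccc2OCCn2ccc(=O)[nH]c2=O)c(C)c2cc(C#N)ccc12` is not yet measured. It differs from compound 3 by methoxy in place of methyl on a saturated chain carbon bound to an aromatic carbon. Going by the values given here, no step between measured compounds isolates this change, so the expectation rests on compound 3 alone. Nothing on record ties such a change to tolerance in this assay, and the expected step of a 1.3-fold higher number from compound 3 to compound 4 (0.10 log units; within the scatter) is none beyond the scatter. Compound 4 is therefore expected to give about 15000 nM in this assay, with an estimated range of 5000 nM to 50000 nM.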

Compound 4, half-maximal cytotoxic concentration: 16000 nM
Compound 4: middle estimate off by 1.1-fold (0.03 log units), on the low side; the range from low to high includes it.
By their numbers in this assay, from the lowest: compounds 1, 3 and 4 (each within the scatter of the next, the first and the last beyond it). At a limit, above all of these: compound 2.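

Replacing methyl with methoxy on a saturated chain carbon bound to an aromatic carbon, which amounts to ethyl giving way to methoxymethyl, gives a 1.3-fold higher number from compound 3 to compound 4 (0.12 log units; within the scatter) in this assay. Going by these compounds alone, this is the first step that isolates a single change, and it shows that this position accepts the extra oxygen, a hydrogen-bond acceptor, with compound 3 and compound 4 standing together. Nothing on record accounts for how this change reads in this assay.

On these data alone, it remains open whether a group of another kind at this position, such as an amine, a carboxylic acid or a longer chain, would also stand with compound 3 and compound 4. As far as these compounds go, it also remains open whether the same exchange of methyl for methoxy would read alike elsewhere on the shared core.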